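Swapping a Bromophenyl Arm for a Dichlorophenyl Arm

The source may report more compounds than this note shows. Statements on the series, on what has been measured and on what is new or still open speak of the compounds shown alone.

Measured compounds:
Compound 2, `COc1ccc(/C=C2\CCC/C(=C\c3cccc(Br)c3)C2=O)cc1OC`: 12800 nM
Compound 1, `COc1cccc(/C=C2\CCC/C(=C\c3ccc(Cl)c(Cl)c3)C2=O)c1OC`: > 20000 nM

Both compounds share a core in which two aromatic arms hang from a ring bearing a carbonyl, and they differ from each other in both arms. In a functional assay on A549 cells (Homo sapiens) for cytotoxicity, read by MTT assay, with a stated time of 72 h (on this read-out lower numbers stand for stronger inhibition and higher numbers for weaker inhibition), compound 2 gives 12800 nM. Compound 1 in this assay gives > 20000 nM, which is a limit of the assay and not a number. Among the measured compounds shown here, compound 2 therefore stands as the only real number in this set; the other value shown is a limit, (the limit of > 20000 nM in this assay, at which 1 of the 2 values shown sits).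

Compound 3, `COc1ccc(/C=C2\CCC/C(=C\c3ccc(Cl)c(Cl)c3)C2=O)cc1OC`, has not yet been measured in this assay. It differs from compound 2 in one place: 3,4-dichlorophenyl in place of 3-bromophenyl on a double-bonded chain carbon bound to a double-bonded ring carbon. For the measured compounds named here, no measured step between two compounds differing in one place is available to gauge this change, so the expectation rests on compound 2 alone. The step is expected to be small, within the scatter or tending toward weaker inhibition, with a 1.2-fold higher number from compound 2 to compound 3 (0.07 log units; within the scatter). Compound 3 is estimated at 15000 nM, in the range 6000 nM to 40000 nM.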

Compound 3, half-maximal inhibitory concentration: 6900 nM
Beside the measured number, compound 3's estimate is 2.2-fold (0.34 log units) above it; the measured number falls inside the stated range.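

In this assay, among the compounds shown here, putting 3,4-dichlorophenyl in place of 3-bromophenyl on a double-bonded chain carbon bound to a double-bonded ring carbon gives a 1.9-fold lower number from compound 2 to compound 3 (0.27 log units; within the scatter), the first measured step at this position. The position therefore takes either arm, 8 heavy atoms or 7 heavy atoms, with no difference that can be told from the ordinary scatter of repeated measurements. The 3,4-dichlorophenyl arm also now stands with a real number in compound 3, whereas compound 1, which carries the same arm but a different second arm, gives a limit of the assay and not a number: the limit of > 20000 nM in this assay, at which 1 of the 3 values shown sits.

From the compounds shown here alone, the step from compound 1 to compound 3 cannot be read, so what the second arm contributes remains open. Both arms measured at this position carry only halogens on the aromatic ring, and one step within the scatter does not tell how an arm bearing an amine or a carboxylic acid would behave there.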